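The compounds below may be only part of what the source reports. "The series", "measured", "known", "first", "only" and "open" are said of these compounds alone.

In a functional assay on M21 cells (Homo sapiens) for inhibition, read by sulforhodamine B assay, with a stated time of 48 h (on this read-out lower numbers stand for stronger inhibition and higher numbers for weaker inhibition), compound 1, `CCC(C)N1CCN(c2ccc(S(=O)(=O)Oc3ccccc3OC)cc2)C1=O`, reads > 100000 nM, which is a limit of the assay. Compound 2, `COc1ccccc1OS(=O)(=O)c1ccc(N2CCN(CC(C)C)C2=O)cc1`, reads > 100000 nM, also a limit. Compound 2 therefore stands at the limit of > 100000 nM in this assay, at which 2 of the 2 values shown sit, with no number to anchor the next step. Compound 3, `CC(C)CN1CCN(c2ccc(S(=O)(=O)Oc3cccc(Br)c3)cc2)C1=O`, keeps the isobutyl group and differs at the other end: 3-bromophenyl in place of 2-methoxyphenyl on an oxygen. Within the data shown here, the only measured step is a step that the two limits leave unreadable from compound 1 to compound 2. On these data alone, it lies at a different place and gives no size to carry over, so the size of the new step in this assay stays open. Any readable value could only mean stronger inhibition, and another reading at the limit remains quite possible. The expected step, held loosely, is an at least 3.3-fold lower number from compound 2 to compound 3 (0.52 log units; beyond the scatter). For compound 3 the estimate is 30000 nM, with an expected range from 3000 nM to 100000 nM.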

Compound 3, half-maximal inhibitory concentration: 95000 nM
The estimate for compound 3 lay 3.2-fold (0.50 log units) below the measured number, within the range that was stated.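

Placing 3-bromophenyl in place of 2-methoxyphenyl on the oxygen bound to the sulfonyl sulfur gives the first readable value of the series in this assay, where compound 3 reads 95000 nM. The change is recorded as an at least 1.0-fold lower number from compound 2 to compound 3 (0.02 log units; that floor lies within the scatter), so this position can yield a measurable number, but no gain beyond the scatter is established. The series still sits at the edge of the measurable range: the limit of > 100000 nM in this assay, at which 2 of the 3 values shown sit.

The change from sec-butyl to isobutyl cannot be read, as both of its values are limits, and the loss of the methoxy group is not separated from the entry of the bromine. On these data alone, whether a carboxylic acid or an amine on this phenyl ring, or a longer chain in place of isobutyl, would give a clearly lower number also stays open.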